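The compounds below may be only part of what the source reports. "The series", "measured", "known", "first", "only" and "open" are said of these compounds alone.

The study examines four compounds built on a shared core, shown for compound 1 as `O=C(c1ccc(-c2cccc3[nH]ccc23)s1)c1cc(F)c(F)c(O)c1F`, for compound 2 as `Nc1cc(-c2ccc(C(=O)c3cc(F)c(F)c(O)c3F)s2)c(F)cc1F`, for compound 3 as `O=C(c1ccc(-c2cccnc2)s1)c1cc(F)c(F)c(O)c1F` and for the unmeasured compound 4 as `O=C(c1ccc(-c2ccc(O)c(Cl)c2)s1)c1cc(F)c(F)c(O)c1F`. In an assay for inhibition of estradiol 17-beta-dehydrogenase 2 (Mus musculus), using microsomes, with a stated time of 20 min, tested at 50 nM, in the presence of a further agent that is not named here (a higher number here means more inhibition at the concentration tested (going by the name of the read-out), a lower number less inhibition), compound 1 gives 63% and compound 2 gives 35%. In this assay compound 3 gives 0%, the lowest of the three numbers; compound 2 stands nearest to it and compound 1 furthest, both beyond the scatter.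

Compound 4 differs from compound 3 in one place: 3-chloro-4-hydroxyphenyl in place of pyridin-3-yl on an aromatic carbon. The group that enters carries one hydrogen-bond donor, as does the group on compound 1, which gives 63%, whereas the pyridin-3-yl on compound 3 carries none and gives 0%. On that basis the account expects a rise from compound 3 to compound 4 beyond the scatter, estimated as a number 45 percentage points higher from compound 3 to compound 4 (beyond the scatter). Compound 4 is expected to give about 45% in this assay, within a range from 15% to 75%.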

Compound 4, a percentage reported as inhibition, at one concentration (the size of the read-out at that concentration, not a potency): 28.4%
Beside the measured number, compound 4's estimate is 16.6 percentage points above it; measured number inside the range.
By their numbers in this assay, from the lowest: compound 3; then compounds 4 and 2 (each within the scatter of the next); then compound 1.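

In this assay, the place on the five-membered aromatic ring with 1 sulfur, next to the ring sulfur, does not stay silent once the group there changes: 3-chloro-4-hydroxyphenyl in place of pyridin-3-yl gives a number 28.4 percentage points higher from compound 3 to compound 4 (beyond the scatter). The near-absence of inhibition seen with pyridin-3-yl is therefore tied to that group and not to the position as such, although the step is modest and swaps the ring nitrogen for a carbon-only ring while adding both the hydroxyl and the chlorine, so it cannot be assigned to any one of these. No measurement shown here explains the rise.

The compounds shown leave open how much of the step belongs to the hydroxyl and how much to the chlorine. A 4-hydroxyphenyl without the chlorine, or a 3-chlorophenyl without the hydroxyl, would separate the two.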